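Swapping Phenethyl for 3-Hydroxyphenyl on a Carbonyl Carbon

This account rests on a few compounds, and the source may have more. Where it says the series, first, only, none or still open, it means among the compounds named here.

Compound 1 (`COc1ccc(-c2cnc(NC(=O)c3cccc([N+](=O)[O-])c3)n2C)cc1`) gives > 100000 nM in a toxicity assay on THP-1 cells (Homo sapiens) for inhibition (a higher number here means that more compound is tolerated, a lower number that less compound is tolerated), and this is a limit, not a number. Compound 2 (`COc1ccc(-c2cnc(NC(=O)CCc3ccccc3)n2C)cc1`) gives > 100000 nM in this assay, and this too is only a limit. Compound 3 (`COc1ccc(-c2cnc(NC(=O)c3cccc(O)c3)n2C)cc1`) carries 3-hydroxyphenyl in place of phenethyl on a carbonyl carbon. Among the measured compounds shown here, no measured step shows what such a swap does, so the expectation rests on (the limit of > 100000 nM in this assay, at which 2 of the 2 values shown sit). The expected step of a number no higher from compound 2 to compound 3 (the limit leaves the size open) stays within the usual scatter, with no clear direction. For compound 3 the estimate is 100000 nM, with an expected range from 40000 nM to 200000 nM.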

Compound 3, half-maximal cytotoxic concentration: > 100000 nM
Compound 3: no number, only a limit (the forecaster's own chance of this, stated with the estimate: 75%); the middle value sits exactly at the limit.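

Among the compounds shown here, compound 1, compound 2 and compound 3 each give only a limit in this assay, so no step between them can be read. The compounds shown leave open whether swapping these groups changes how much compound the cells tolerate.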